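The source may hold more compounds than are shown below. What is called first, only, known or untested is meant among the compounds shown, and "the series" means these compounds.

In an ADME assay on NIH3T3 cells (Mus musculus) for inhibition, read by sulforhodamine B assay, with a stated time of 48 h (on this read-out higher numbers stand for weaker inhibition of growth and lower numbers for stronger inhibition of growth), compound 1 (`COc1cc(C(=O)NNC(=O)c2ccc3[nH]c(-c4ccc([N+](=O)[O-])s4)nc3c2)cc(OC)c1OC`) gives 31.3 ug/mL, level with compound 3 (`O=C(NNC(=O)c1cc2ccccc2cc1O)c1ccc2[nH]c(-c3ccc([N+](=O)[O-])s3)nc2c1`) at 31.3 ug/mL. Compound 2 (`O=C(O)c1ccc2[nH]c(-c3ccc([N+](=O)[O-])o3)nc2c1`) gives 62.5 ug/mL, and all three values lie within the usual scatter of one another. Compound 4 (`COc1cc(C(=O)NNC(=O)c2ccc3[nH]c(-c4ccc([N+](=O)[O-])o4)nc3c2)cc(OC)c1OC`) differs from compound 1 by having 5-nitrofuran-2-yl in place of 5-nitrothiophen-2-yl on an aromatic carbon. For the measured compounds named here, no measured pair isolates this change, so the series offers no direct step to carry over. Nothing beyond the scatter is expected in this assay for no change at the digits printed from compound 1 to compound 4 (within the scatter), and neither direction is favoured. Compound 4 is estimated at 31.3 ug/mL, with an expected range of 12 ug/mL to 85 ug/mL.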

Compound 4, concentration for 50% growth inhibition: 31.3 ug/mL
Beside the measured number, compound 4's estimate shows no gap at the digits printed; low and high end bracket the measured number.
By their numbers in this assay, from the lowest: compounds 1, 3, 4 and 2 (each within the scatter of the next).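

In this assay, for the compounds shown here, the swap of 5-nitrothiophen-2-yl for 5-nitrofuran-2-yl gives no change at the digits printed from compound 1 to compound 4 (within the scatter) with the rest of the molecule held constant, the only direct reading of this change. At this place, on an aromatic carbon between two ring nitrogen atoms, the read-out therefore does not separate the two rings. Nothing available explains this match.

From the compounds shown here alone, whether an amine in place of the nitro group would keep the value level remains open. So does the outcome for a plain phenyl ring at this place.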